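A few compounds are considered here, and "the series" means these few. Any claim that something is new, unique, unknown or untested is made for them only; others in the source may bear on it.

Three compounds have been measured in an assay on mitochondria for inhibition of Amine oxidase [flavin-containing] A (Bos taurus); on this read-out lower numbers stand for stronger inhibition and higher numbers for weaker inhibition:

compound 1, `Cc1csc(N/N=C/c2ccc(Cl)cc2)n1`, gives 38 nM
compound 2, `Clc1ccc(/C=N/Nc2nc(-c3ccccc3)cs2)cc1`, gives 100 nM
compound 3, `Cc1ccc(/C=N/c2nc(C)cs2)cc1`, gives 204 nM

Compound 1 and compound 2 differ in one place: phenyl in place of methyl on an aromatic carbon. That change brings a 2.6-fold higher number from compound 1 to compound 2 (0.42 log units; beyond the scatter), so the phenyl compound gives the weaker inhibition in this pair. Compound 3 has the highest number of the three; against compound 2 its number is higher by a step beyond the scatter, and against compound 1 by a larger one. The difference between the core of compound 1 and the core of compound 3 is not broken down here.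

Compound 4, `Cc1ccc(/C=N/c2nc(-c3ccccc3)cs2)cc1`, has not yet been measured in this assay. It relates to compound 3 as compound 2 relates to compound 1: phenyl in place of methyl on an aromatic carbon. The surroundings are not the same word for word, since in the pair from compound 1 the ring atom two ring bonds away bears a large group, whereas in the pair from compound 3 it bears a group of 9 heavy atoms, so this is the same kind of change rather than the same change. Among the measured compounds shown here, on that footing, the step is expected to be a 2.6-fold higher number from compound 3 to compound 4 (0.41 log units; beyond the scatter), resting on the single earlier example, compound 1 to compound 2 with a 2.6-fold higher number from compound 1 to compound 2 (0.42 log units; beyond the scatter), and on compound 3 giving 204 nM as the starting point. For compound 4 the expected value is 530 nM, with a likely range from 250 nM to 1200 nM.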

Compound 4, inhibition constant: 21.4 nM
The estimate for compound 4 lay 25-fold (1.39 log units) above the measured number; the measured number lies below the stated range.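

In this assay, putting phenyl in place of methyl on an aromatic carbon brings a 9.5-fold lower number from compound 3 to compound 4 (0.98 log units; beyond the scatter), so on this core the phenyl compound gives the stronger inhibition, whereas on the core of compound 1 it gives the weaker. Set side by side, the two results show that this change does not carry over from one core to the other in either size or direction: the same change on two cores in this assay, a 2.6-fold higher number (0.42 log units; beyond the scatter) from compound 1 to compound 2 and a 9.5-fold lower number (0.98 log units; beyond the scatter) from compound 3 to compound 4, 25-fold (1.40 log units) apart, beyond the scatter of two such steps Each core supplies only one pair, however, so the data do not show which feature of the cores decides the outcome, or what the same change would do on a further core.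

The compounds shown leave open how groups of other kinds would behave on this aromatic carbon, such as an amine, a carboxylic acid or a longer alkyl chain, and whether any of them would follow the same opposite trends on the two cores. Also open, going by these compounds, is which difference between the core of compound 1 and the core of compound 3 matters, a question that compounds changed in only one place at a time could help to settle.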